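This account rests on a few compounds, and the source may have more. Where it says the series, first, only, none or still open, it means among the compounds named here.

In a functional assay on SW982 cells (Homo sapiens) for inhibition, read by MTT assay, with a stated time of 72 h (a lower number here means a stronger inhibitor, a higher number a weaker inhibitor), compound 2 `COc1ccc(C(=O)/C=C/c2cc(OC)c(OC)cc2OC)cc1` gives 60500 nM, which stands as the higher of the two numbers obtained, though its nearest neighbour, compound 1 `COc1cc(OC)c(OC)cc1/C=C/C(=O)c1ccc(Cl)cc1`, gives 58500 nM, a gap within the scatter. Compound 3 `COc1cc(OC)c(-c2cc(=O)c3ccc(O)cc3o2)cc1OC` gives only a limit, > 150000 nM. For the measured compounds named here, the single measured step, a 1.0-fold higher number from compound 1 to compound 2 (0.01 log units; within the scatter), is the only one that bears on the change to compound 4 `COc1cc(OC)c(OC)cc1/C=C/C(=O)c1ccc(-c2c[nH]cn2)cc1`, which is 1H-imidazol-4-yl in place of methoxy on an aromatic carbon. Going by the values given here, that step lies within the scatter, so one exchange at this position has not moved the number; the entering group is larger and carries a hydrogen-bond donor, but no measured step tells how that will act. Compound 4 is therefore expected to show a 1.3-fold lower number from compound 2 to compound 4 (0.13 log units; within the scatter), at an estimated 45000 nM, ranging from 15000 nM to 150000 nM.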

Compound 4, half-maximal inhibitory concentration: > 150000 nM
Compound 4 ended at the assay's limit; the forecaster's own chance of this, stated with the estimate: 15%; at least 3.3-fold (0.52 log units) between middle value and limit.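

The value of compound 4, > 150000 nM, is a limit of the assay and not a number. Where chloro and methoxy at this position stayed within the scatter of each other, 1H-imidazol-4-yl gives an at least 2.4-fold higher number from compound 2 to compound 4 (0.39 log units; beyond the scatter) and an at least 2.5-fold higher number from compound 1 to compound 4 (0.40 log units; beyond the scatter), so the position does respond to the group it carries. How large these steps really are stays hidden: the limit of > 150000 nM in this assay, at which 2 of the 4 values shown sit.

From the compounds shown here alone, whether an amine or a carboxylic acid here would stay close to compound 1 and compound 2 remains open. So does whether a phenyl ring, with no hetero atoms, would behave like 1H-imidazol-4-yl.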